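Ethoxy to Dimethylamino: From Compound 3 to Compound 4

The source may report more compounds than this note shows. Statements on the series, on what has been measured and on what is new or still open speak of the compounds shown alone.

Compound 3 `CCOc1ccc(-c2cccc(NC(=O)N(C)C)c2)cc1` gives 70000 nM in an assay on COS-7 cells for inhibition of patatin-like phospholipase domain-containing protein 2 (Mus musculus); on this read-out higher numbers stand for weaker inhibition and lower numbers for stronger inhibition; it stands second highest of the three numbers, nearest to compound 1 `CCOC(=O)c1cccc(-c2ccc(OCC)cc2)c1`, which gives 50000 nM, and furthest from compound 2 `CCOc1ccc(-c2cccc(C(=O)N3CCCC3)c2)cc1`, which gives 160000 nM. Compound 4 `CN(C)C(=O)Nc1cccc(-c2ccc(N(C)C)cc2)c1` differs from compound 3 by dimethylamino in place of ethoxy on an aromatic carbon. Going by the values given here, the measured steps all alter the carbonyl side of the shared core: a 3.2-fold higher number from compound 1 to compound 2 (0.51 log units; beyond the scatter), a 1.4-fold higher number from compound 1 to compound 3 (0.15 log units; within the scatter) and a 2.3-fold lower number from compound 2 to compound 3 (0.36 log units; beyond the scatter); none of them touches the ethoxy group, so no measured step bears directly on this change. Compound 4 is therefore expected to show no step beyond the scatter, no change at the digits printed from compound 3 to compound 4 (within the scatter). The estimate for compound 4 in this assay is 70000 nM, with a range from 25000 nM to 200000 nM.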

Compound 4, half-maximal inhibitory concentration: < 5000 nM
Compound 4: no number, only a limit; the forecaster's own chance of this, stated with the estimate: 15%; middle value at least 14-fold (1.14 log units) away from the limit.
By their numbers in this assay, from the lowest: compounds 1 and 3 (each within the scatter of the next); then compound 2. At a limit, below all of these: compound 4.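

Dimethylamino in place of ethoxy, para to a large group, gives an at least 14-fold lower number from compound 3 to compound 4 (1.14 log units; beyond the scatter) in this assay, a larger step than any made on the carbonyl side of the shared core. Compound 4 gives < 5000 nM, which is a limit and not a number. The two groups match in heavy-atom count, donors, acceptors and net charge, so these counts do not separate them.

Going by these compounds, whether a primary amine, methoxy or diethylamino here would give a similar step remains open. So does whether dimethylamino would act alike with the ester or pyrrolidine amide of compound 1 and compound 2.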